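The source may report more compounds than this note shows. Statements on the series, on what has been measured and on what is new or still open speak of the compounds shown alone.

Working notes on the series.

Compound 1 `N#Cc1c(Nc2ccccc2Cl)nc(SCc2cn(Cc3ccccc3Cl)nn2)nc1-c1ccccc1` is the reference. In a functional assay on MCF7 cells (Homo sapiens) for inhibition, read by MTT assay, with a stated time of 72 h (a lower number here means a stronger inhibitor, a higher number a weaker inhibitor), compound 1 gives 1950 nM. Compound 2 `N#Cc1c(Nc2ccccc2F)nc(SCc2cn(Cc3ccccc3Cl)nn2)nc1-c1ccccc1` differs from compound 1 by fluoro in place of chloro on an aromatic carbon, and in this assay compound 2 gives 8060 nM; the step is a 4.1-fold higher number from compound 1 to compound 2 (0.62 log units; beyond the scatter).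

Compound 3 `Cc1ccc(Nc2nc(SCc3cn(Cc4ccc(Cl)cc4)nn3)nc(-c3ccccc3)c2C#N)cc1` carries a different core, and how it differs from compound 1 is not broken down here. In this assay compound 3 reaches only a limit, > 64000 nM, not a number; this is the limit of > 64000 nM in this assay, at which 1 of the 3 values shown sits.

Compound 4 `Cc1ccc(Nc2nc(SCc3cn(Cc4ccc(F)cc4)nn3)nc(-c3ccccc3)c2C#N)cc1`, not yet measured, differs from compound 3 by fluoro in place of chloro on an aromatic carbon. This is the same kind of change as from compound 1 to compound 2, but not the same: there the place was ortho to a large group, here it is para to a large group. The earlier step weakened inhibition modestly, so the expected direction from compound 3 is toward a weaker inhibitor or no change. Since compound 3 already sits at the limit of > 64000 nM in this assay, at which 1 of the 3 values shown sits, compound 4 is expected to report only a limit as well. The expected step is a step that the limit leaves unreadable from compound 3 to compound 4. Compound 4 is estimated at 120000 nM, between 40000 nM and 400000 nM.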

Compound 4, half-maximal inhibitory concentration: 51100 nM
Estimate against measurement, compound 4: 2.3-fold (0.37 log units) above, within the range that was stated.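

In this assay compound 3 reports only a limit, > 64000 nM, not a number. Fluoro in place of chloro on this core therefore reads as an at least 1.2-fold lower number from compound 3 to compound 4 (0.09 log units; that floor lies within the scatter), so only a floor is available and the true size of the step stays unknown. Carried from one core to the other, the same change does not give the same result, but this single pair of steps cannot tell whether the core or the place of the change sets the gap: the same change on two cores in this assay, a 4.1-fold higher number (0.62 log units; beyond the scatter) from compound 1 to compound 2 and an at least 1.2-fold lower number (0.09 log units; that floor lies within the scatter) from compound 3 to compound 4, at least 5.1-fold (0.71 log units) apart, beyond the scatter of two such steps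

For the compounds shown here, each core offers only one such pair, so it remains open how the change would read at both places on a single core. Also open, from the compounds shown here alone, is whether a methoxy group or an amine in place of the chloro of the 4-chlorobenzyl group would give a measured number rather than a limit in this assay.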